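A few compounds are considered here, and "the series" means these few. Any claim that something is new, unique, unknown or untested is made for them only; others in the source may bear on it.

Measured so far in an ADME assay on NIH3T3 cells (Mus musculus) for cytotoxicity, read by MTT assay, with a stated time of 24 h; a lower number here means a stronger inhibitor, a higher number a weaker inhibitor:
Compound 1 `O=C(CSc1nnc(COc2ccc3c(c2)CCCC3)o1)Nc1nc2ccc(F)cc2s1`: 292000 nM
Compound 2 `CCOc1ccc2nc(NC(=O)CSc3nnc(COc4ccc5c(c4)CCCC5)o3)sc2c1`: > 403000 nM, a limit of the assay

Within the data shown here, compound 1 carries the only number in this pair that is not a limit. For compound 2, this assay gives (the limit of > 403000 nM in this assay, at which 1 of the 2 values shown sits). Compound 3 `O=C(CSc1nnc(COc2ccc3c(c2)CCCC3)o1)Nc1nccs1` has not yet been measured. It differs from compound 1 in one place: 1,3-thiazol-2-yl in place of 6-fluoro-1,3-benzothiazol-2-yl on an amide-type nitrogen. Among the measured compounds shown here, only one measured step bears on this change, and only loosely: an at least 1.3-fold higher number from compound 1 to compound 2 (0.13 log units; that floor lies within the scatter). That step swaps ethoxy for fluoro on an aromatic carbon, whereas compound 3 replaces the whole 6-fluoro-1,3-benzothiazol-2-yl group. No step beyond the scatter is therefore expected in this assay, in either direction. The expected change is a 1.0-fold lower number from compound 1 to compound 3 (0.02 log units; within the scatter). For compound 3 the estimated value is 280000 nM, with an expected range of 130000 nM to 550000 nM.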

Compound 3, half-maximal inhibitory concentration: > 403000 nM
Compound 3 gave a limit, no number; the forecaster's own chance of this, stated with the estimate: 25%; middle value at least 1.4-fold (0.15 log units) from the limit.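

In this assay, the earlier step changed only a substituent, whereas this change removes the whole 6-fluoro-1,3-benzothiazol-2-yl group, and with it the six-membered aromatic ring of carbon only, from the amide-type nitrogen. Even so, the result is an at least 1.3-fold higher number from compound 1 to compound 3 (0.13 log units; that floor lies within the scatter). This shows that a much larger change at this position also gives no lower number than compound 1, although the size of any rise cannot be read. Compound 3 is the second compound to end at a limit rather than a number: the limit of > 403000 nM in this assay, at which 2 of the 3 values shown sit.

The compounds shown leave open whether any other group on the amide-type nitrogen, such as phenyl, pyridin-2-yl or a simple methyl, would give a measurable number. They also do not show whether an amine or a carboxylic acid on the 1,3-thiazol-2-yl group would do so.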